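A few compounds are considered here, and "the series" means these few. Any claim that something is new, unique, unknown or untested is made for them only; others in the source may bear on it.

Series notes on the shared core of compound 1, `CC#C[C@H]1CN(S(=O)(=O)c2ccc(N)nc2)CCN1c1ccc(C(O)(COC)C(F)(F)F)cc1`. The read-out throughout is an assay on cells (Hepatocyte) for inhibition of glucokinase regulatory protein (Mus musculus), with stated times of 20 min and 40 min; on this read-out higher numbers stand for an effect only at larger amounts of compound and lower numbers for an effect already at smaller amounts. In this assay compound 1 gives 202 nM. Compound 2, `CC#C[C@H]1CN(S(=O)(=O)c2ccc(N)nc2)CCN1c1ccc([C@@](O)(CO)C(F)(F)F)cc1`, gives 89 nM in this assay, a change of a 2.3-fold lower number from compound 1 to compound 2 (0.36 log units; beyond the scatter). Compound 3, `CC#C[C@H]1CN(S(=O)(=O)c2ccc(N)nc2)CCN1c1ccc([S+](C)[O-])cc1`, reaches only a limit of this assay, > 12500 nM, and no number. Compound 3 therefore stands at the weak end of the three values shown, sitting at the limit of > 12500 nM in this assay, at which 1 of the 3 values shown sits. The two steps leading to it, an at least 61-fold higher number from compound 1 to compound 3 (1.79 log units; beyond the scatter) and an at least 140-fold higher number from compound 2 to compound 3 (2.14 log units; beyond the scatter), are both large.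

Compound 4, `CC#C[C@H]1CN(S(=O)(=O)c2ccc(N)nc2)CCN1c1ccc(S(C)(=N)=O)cc1`, differs from compound 3 in one place: a group of 4 heavy atoms (1 carbon, 1 nitrogen, 1 oxygen, 1 sulfur; no ring) in place of a group of 3 heavy atoms (1 carbon, 1 oxygen, 1 sulfur; no ring), on an aromatic carbon. The group that enters carries one hydrogen-bond donor and two hydrogen-bond acceptors, against no donor and one acceptor in the group that leaves, and sits para to a large group. Among the measured compounds shown here, the steps that bear on this change are those into compound 3, both large and both ending at a limit. For the measured compounds named here, no measured pair separates one small substituent at this position from another, so the change has no direct precedent. Compound 4 is expected to remain near the limit of this assay. For compound 4 the expected step is a step that the limit leaves unreadable from compound 3 to compound 4, none beyond the scatter. The estimate for compound 4 in this assay is 15000 nM, in a range from 4000 nM to 50000 nM.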

Compound 4, half-maximal effective concentration: 704 nM
Estimate against measurement, compound 4: 21-fold (1.33 log units) above, and the stated range ends above it.
By their numbers in this assay, from the lowest: compound 2; then compound 1; then compound 4. At a limit, above all of these: compound 3.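

In this assay, a small group on the aromatic carbon para to a large group does not by itself abolish the effect, as the sulfur-bearing group of compound 3 had suggested: the exchange that adds one nitrogen and one hydrogen-bond donor gives an at least 17-fold lower number from compound 3 to compound 4 (1.24 log units; beyond the scatter). The two larger groups carrying the trifluoromethyl still give lower numbers than the group of 4 heavy atoms, but the gaps are far smaller than the steps into compound 3 and are a 3.5-fold higher number from compound 1 to compound 4 (0.54 log units; beyond the scatter) and a 7.9-fold higher number from compound 2 to compound 4 (0.90 log units; beyond the scatter), both modest and beyond the scatter, so a group of this size with no ring can hold a measurable value. Compound 3 remains the only compound here at a limit, which is not a number, and the step out of it is therefore a bound and not a measured size: the limit of > 12500 nM in this assay, at which 1 of the 4 values shown sits.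

The compounds shown do not separate the contribution of the added nitrogen from that of its hydrogen, and a single pair carries the whole finding. Going by these compounds, what a methyl sulfone, a primary amide or a carboxylic acid would give at this position remains open.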